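The compounds below may be only part of what the source reports. "The series", "measured", "known", "first", "only" and "open" are said of these compounds alone.

Going by the values given here, in a functional assay on HT-29 cells (Homo sapiens) for inhibition, read by sulforhodamine B assay, with a stated time of 48 h (a lower number here means a stronger inhibitor of growth, a higher number a weaker inhibitor of growth), three compounds built on one shared core have numbers so far. Compound 3 `CCCc1ccc(C2NC(=O)NC(C)=C2C(=O)OCC)cc1` gives 17.5 ug/mL in this test. Compound 1 `CCOC(=O)C1=C(C)NC(=O)NC1c1ccc(SC)cc1` gives 10.2 ug/mL and lies within the scatter of compound 3. Compound 2 `CCOC(=O)C1=C(C)NC(=O)NC1c1ccc(O)c(O)c1` gives 37.8 ug/mL and stands beyond the scatter of compound 3, on the side of weaker inhibition.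

The next step leads to compound 4 `CCOC(=O)C1=C(C)NC(=O)NC1c1ccc(O)cc1`, which has hydroxy in place of propyl on an aromatic carbon, para to a large group. Among the compounds with values here, only one measured step involves that aromatic carbon, and it exchanges methylsulfanyl for propyl. It is small (a 1.7-fold higher number from compound 1 to compound 3 (0.23 log units; within the scatter)) and says little about hydroxy, which takes no part in it. Hydroxy appears only in compound 2, which carries more on its ring than compound 4 does, so no measured pair isolates this change.

A modest step towards a higher number in this assay is expected, because compound 2 gives 37.8 ug/mL with hydroxy on its ring. The expected size is a 1.6-fold higher number from compound 3 to compound 4 (0.20 log units; within the scatter) and it may not clear the scatter. For compound 4 the estimated value is 28 ug/mL (expected range 12 ug/mL to 60 ug/mL).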

Compound 4, concentration for 50% growth inhibition: 28.7 ug/mL
For compound 4 the middle estimate is 1.0-fold (0.01 log units) below the measured one, within the range that was stated.
By their numbers in this assay, from the lowest: compounds 1, 3, 4 and 2 (each within the scatter of the next, the first and the last beyond it).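

Taken alone, the exchange gives a 1.6-fold higher number from compound 3 to compound 4 (0.21 log units; within the scatter) in this assay, so propyl and hydroxy cannot be told apart at this aromatic carbon, and taking the extra hydroxy away from compound 2 likewise gives only a 1.3-fold lower number from compound 2 to compound 4 (0.12 log units; within the scatter) and no clear change. Hydroxy in place of methylsulfanyl gives a 2.8-fold higher number from compound 1 to compound 4 (0.45 log units; beyond the scatter) and is the only step at this position that clears the scatter, so two steps that are each too small to read on their own, from methylsulfanyl to propyl and from propyl to hydroxy, add up to a real if modest loss of growth inhibition. Nothing available explains why these groups rank as they do.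

On these data alone, whether an amine, a carboxylic acid or a longer chain at this aromatic carbon would move the number further in either direction remains open. Also open, as far as these compounds go, is how methoxy would compare with methylsulfanyl and with hydroxy in this assay, which would help show whether the edge of compound 1 over compound 4 is specific to methylsulfanyl.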